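From cyclopentyl to isopropyl on compound 2

The source may hold more compounds than are shown below. What is called first, only, known or untested is meant among the compounds shown, and "the series" means these compounds.

In an ADME assay on a cell-free system (plasma, Rattus norvegicus) for metabolic stability, read by LC-MS, with a stated time of 60 min, tested at 100 uM (a lower number here means that less of the compound is left, a higher number that more of the compound is left), compound 1 `Cc1c(OCCCCOc2ccc(C(=O)O)cc2F)ccc(C(=O)CC2CCCC2)c1O` gives 97% and compound 2 `Cc1c(OCCCCOc2ccc(C(=O)O)cc2Cl)ccc(C(=O)CC2CCCC2)c1O` gives 120%, the higher of the two numbers. Compound 3 `Cc1c(OCCCCOc2ccc(C(=O)O)cc2Cl)ccc(C(=O)CC(C)C)c1O` carries isopropyl in place of cyclopentyl on a saturated chain carbon bound to a carbonyl carbon. Within the data shown here, the only measured step, a number 23 percentage points higher from compound 1 to compound 2 (beyond the scatter), came from chloro in place of fluoro on an aromatic carbon, a different change, so it offers little guidance. Among the measured compounds shown here, no measured step covers the new change, so no shift beyond the scatter is expected. The estimated step is a number 8 percentage points lower from compound 2 to compound 3 (within the scatter). For compound 3 the expected value is 112%, with an estimated range from 92% to 128%.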

Compound 3, percent of the compound remaining: 123%
For compound 3 the middle estimate is 11 percentage points below the measured one, within the range that was stated.
By their numbers in this assay, from the lowest: compound 1; then compounds 2 and 3 (each within the scatter of the next).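

Taking out the ring at this saturated chain carbon bound to a carbonyl carbon gives a number 3 percentage points higher from compound 2 to compound 3 (within the scatter) in this assay. Here, then, the cyclopentyl ring is not needed to hold this read-out, and the smaller isopropyl serves as well. Nothing available explains this result.

Still open, from the compounds shown here alone, is whether a different group at this place, such as an amine or a longer chain like hexyl, would also stay within the scatter. Also open, going by these compounds, is whether isopropyl would behave the same way alongside fluoro rather than chloro.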